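The source may hold more compounds than are shown below. What is called first, only, known or untested is meant among the compounds shown, and "the series" means these compounds.

Measured in an ADME assay on HEK-293T cells (Homo sapiens) for cytotoxicity, read by resazurin assay, with a stated time of 16 h; on this read-out lower numbers stand for stronger inhibition and higher numbers for weaker inhibition:
- Compound 1 `OC[C@H]1O[C@@H](n2cnc3c(NC4CCCC4)nc(NC4CCCCCC4)nc32)[C@H](O)[C@@H]1O`: 167000 nM
- Compound 2 `OC[C@H]1O[C@@H](n2cnc3c(NC4CCCC4)nc(NC4CCCC4)nc32)[C@H](O)[C@@H]1O`: > 500000 nM, a limit
- Compound 3 `OC[C@H]1O[C@@H](n2cnc3c(NC4CCCC4)nc(NC4CC4)nc32)[C@H](O)[C@@H]1O`: > 500000 nM, a limit

Compound 3 has no exact number, only a limit of the assay. It stands at the limit of > 500000 nM in this assay, at which 2 of the 3 values shown sit.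

Compound 4 `OC[C@H]1O[C@@H](n2cnc3c(NC4CCCC4)nc(NC4CCCCC4)nc32)[C@H](O)[C@@H]1O` alters one group of compound 3: cyclohexyl in place of cyclopropyl on a nitrogen on an aromatic ring. Cyclohexyl comes in place of cyclopropyl on a nitrogen on an aromatic ring.

Among the compounds with values here, three measured steps concern this same place. Replacing cycloheptyl with cyclopentyl gave an at least 2.9-fold higher number from compound 1 to compound 2 (0.47 log units; beyond the scatter). Replacing cycloheptyl with cyclopropyl gave an at least 2.9-fold higher number from compound 1 to compound 3 (0.47 log units; beyond the scatter). Between the two smaller rings, the result is a step that the two limits leave unreadable from compound 2 to compound 3.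

Cyclohexyl is larger than cyclopentyl and smaller than cycloheptyl, the only group here to give an exact number, with compound 1 at 167000 nM. Compound 4 is therefore expected to fall near the limit, perhaps still at it, or somewhat toward compound 1. The expected change in this assay is small and toward a lower number: an at least 1.6-fold lower number from compound 3 to compound 4 (0.22 log units; that floor lies within the scatter). Compound 4 is estimated at 300000 nM, with an expected range of 130000 nM to 700000 nM.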

Compound 4, half-maximal inhibitory concentration: 228000 nM
The estimate for compound 4 lay 1.3-fold (0.12 log units) above the measured number, and the stated range covers the measured number.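

In this assay, cyclohexyl on this nitrogen gives an exact number where cyclopropyl and cyclopentyl reach only the limit of the assay, as an at least 2.1-fold lower number from compound 3 to compound 4 (0.34 log units; beyond the scatter) and an at least 2.1-fold lower number from compound 2 to compound 4 (0.34 log units; beyond the scatter) show. Compound 2 and compound 3 each hold only a limit, so both of these steps give a minimum size, not a true one: the limit of > 500000 nM in this assay, at which 2 of the 4 values shown sit. Cyclohexyl and cycloheptyl cannot be told apart here, with a 1.4-fold higher number from compound 1 to compound 4 (0.14 log units; within the scatter), so the change from a limit to an exact number now lies between cyclopentyl and cyclohexyl, not only between cyclopentyl and cycloheptyl.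

From the compounds shown here alone, whether a still larger ring such as cyclooctyl would lower the number further remains open. So does whether an open hexyl chain on this nitrogen would behave like the cyclohexyl ring.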